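The compounds below may be only part of what the source reports. "The series", "measured", "known", "first", "only" and "open" are said of these compounds alone.

Working notes on the series. The shared core is a benzamide on a piperidine bearing a naphthylmethyl group; compound 1 `O=C(NC1CCN(Cc2ccc3ccccc3c2)CC1)c1ccccc1` carries a plain phenyl on the carbonyl carbon and in a functional assay on CHO cells for inhibition of melanin-concentrating hormone receptor 1 (Homo sapiens), read by calcium flux (a higher number here means a weaker inhibitor, a lower number a stronger inhibitor), compound 1 gives 948 nM. Within the data shown here, compound 2 `COc1cc(OC)cc(C(=O)NC2CCN(Cc3ccc4ccccc4c3)CC2)c1` puts 3,5-dimethoxyphenyl in that place, and in this assay compound 2 gives 62 nM, the lowest of the two numbers; the step of a 15-fold lower number from compound 1 to compound 2 (1.18 log units; beyond the scatter) is the only measured step so far.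

Compound 3 `O=C(NC1CCN(Cc2ccc3ccccc3c2)CC1)c1ccc(F)c(F)c1` changes (3,4-difluorophenyl in place of 3,5-dimethoxyphenyl on a carbonyl carbon). Among the measured compounds shown here, the 3,5-dimethoxyphenyl that drove the gain from compound 1 to compound 2 leaves, and 3,4-difluorophenyl enters; no measured step covers a difluorophenyl, so the one step bearing on this change is the reversal of a 15-fold lower number from compound 1 to compound 2 (1.18 log units; beyond the scatter). The expected direction is upward, with the number of compound 3 expected nearer compound 1 than compound 2, an estimated step of a 6.5-fold higher number from compound 2 to compound 3 (0.81 log units; beyond the scatter). For compound 3 the estimate in this assay is 400 nM, in the range 120 nM to 1500 nM.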

Compound 3, half-maximal inhibitory concentration: 52 nM
Beside the measured number, compound 3's estimate is 7.7-fold (0.89 log units) above it; the whole stated range lies above it.
By their numbers in this assay, from the lowest: compounds 3 and 2 (each within the scatter of the next); then compound 1.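

In this assay the gain at this position does not belong to 3,5-dimethoxyphenyl alone: with 3,4-difluorophenyl on the carbonyl carbon there is an 18-fold lower number from compound 1 to compound 3 (1.26 log units; beyond the scatter). Exchanging the two substituted phenyl groups gives a 1.2-fold lower number from compound 2 to compound 3 (0.08 log units; within the scatter), so groups with 2 and with 0 hydrogen-bond acceptors read alike here, and among these compounds the gain over plain phenyl does not depend on hydrogen-bond acceptors in this group. No measurement at hand explains why these two groups read alike.

Going by these compounds, whether a single methoxy or a single fluorine would be enough remains open, as does the outcome with a different kind of group in this place, such as an amine, a nitrile or a carboxylic acid. The shared core stays fixed throughout, so whether these gains hold with another group in place of naphthylmethyl is also unknown.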